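Adding 2-hydroxyethyl to the core of compound 1

The source may report more compounds than this note shows. Statements on the series, on what has been measured and on what is new or still open speak of the compounds shown alone.

Measured so far in a physicochemical assay for solubility, measured as kinetic solubility, with a stated time of 1 h, at pH 7.4; on this read-out lower numbers stand for lower solubility and higher numbers for higher solubility:
- Compound 1 `O=C(NC1=NN(c2ccc(Cl)c(Cl)c2)CC1)c1cccnc1`: 4000 nM
- Compound 2 `O=C(NC1=NN(c2ccc(Cl)c(Cl)c2)CC1)c1ccnnc1`: 23000 nM

Compound 1 holds the lower of these two numbers. For the measured compounds named here, the only measured step is a 5.8-fold higher number from compound 1 to compound 2 (0.76 log units; beyond the scatter), with pyridazin-4-yl in place of pyridin-3-yl on a carbonyl carbon. Compound 3 `O=C(NC1=NN(c2ccc(Cl)c(Cl)c2)CC1CCO)c1cccnc1` keeps the pyridin-3-yl of compound 1 and differs elsewhere: 2-hydroxyethyl in place of hydrogen on a saturated ring carbon. The measured step lies at a different place in the molecule, so it offers only a rough gauge of size. Going by the values given here, no measured pair tests a change on the saturated ring carbon, and the direction remains open. A step beyond the scatter is therefore not firmly expected, and a slight rise in this assay seems the best guess. The expected change is a 1.5-fold higher number from compound 1 to compound 3 (0.18 log units; within the scatter). For compound 3 the estimated value is 6000 nM, with an expected range from 2000 nM to 20000 nM.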

Compound 3, solubility: 192000 nM
Estimate against measurement, compound 3: 32-fold (1.51 log units) below; the measured number lies above the stated range.
By their numbers in this assay, from the lowest: compound 1; then compound 2; then compound 3.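

On the saturated ring carbon of the core, 2-hydroxyethyl in place of hydrogen moves the number in this assay a long way (a 48-fold higher number from compound 1 to compound 3 (1.68 log units; beyond the scatter)). This shows that the position can respond strongly to a small added chain, and the step is larger than the only earlier one, which lay at the pyridine end of the molecule (a 5.8-fold higher number from compound 1 to compound 2 (0.76 log units; beyond the scatter)). Nothing available explains why the rise is so large.

A single group at this position cannot separate the part played by the hydroxyl from that of the carbon chain, so a plain ethyl group, a longer chain or an amine at the same carbon would be informative. Going by these compounds, it also remains open whether 2-hydroxyethyl would give a similar step when combined with the pyridazin-4-yl of compound 2.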